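A few compounds are considered here, and "the series" means these few. Any claim that something is new, unique, unknown or untested is made for them only; others in the source may bear on it.

Three compounds share one core and differ only in the group attached to a saturated chain carbon bound to a saturated ring carbon. Compound 1 `Cn1ncc(Cl)c1-c1cc(C(=O)N[C@@H]2CN[C@H](CC(=O)O)C[C@H]2c2ccc(Cl)c(Cl)c2)oc1Cl` carries a carboxy group there, and in a functional assay on OVCAR-8 cells (Homo sapiens) for antiproliferative activity (on this read-out higher numbers stand for weaker inhibition and lower numbers for stronger inhibition), compound 1 gives 5120 nM. Compound 2 `Cn1ncc(Cl)c1-c1cc(C(=O)N[C@@H]2CN[C@H](CCO)C[C@H]2c2ccc(Cl)c(Cl)c2)oc1Cl` carries hydroxymethyl instead, and in this assay compound 2 gives 610 nM. Compound 3 `CNC(=O)C[C@@H]1C[C@@H](c2ccc(Cl)c(Cl)c2)[C@H](NC(=O)c2cc(-c3c(Cl)cnn3C)c(Cl)o2)CN1` carries methylcarbamoyl, and in this assay compound 3 gives 1130 nM, the second highest of the three numbers. The measured steps were an 8.4-fold lower number from compound 1 to compound 2 (0.92 log units; beyond the scatter), a 4.5-fold lower number from compound 1 to compound 3 (0.66 log units; beyond the scatter) and a 1.9-fold higher number from compound 2 to compound 3 (0.27 log units; within the scatter).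

Compound 4 `Cn1ncc(Cl)c1-c1cc(C(=O)N[C@@H]2CN[C@H](CCCO)C[C@H]2c2ccc(Cl)c(Cl)c2)oc1Cl` differs from compound 3 in one place: 2-hydroxyethyl in place of methylcarbamoyl on a saturated chain carbon bound to a saturated ring carbon. The step that bears on this most directly is the one that exchanged hydroxymethyl for methylcarbamoyl, a 1.9-fold higher number from compound 2 to compound 3 (0.27 log units; within the scatter), which stayed within the scatter; the change to compound 4 runs the other way and adds a longer hydroxy-bearing chain. A small step down toward the value of compound 2 is therefore expected, but not one beyond the scatter. Compound 4 is expected to give about 650 nM, with a likely range from 250 nM to 1700 nM. That estimate amounts to an expected step of a 1.7-fold lower number from compound 3 to compound 4 (0.24 log units; within the scatter).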

Compound 4, half-maximal inhibitory concentration: 600 nM
Estimate against measurement, compound 4: 1.1-fold (0.03 log units) above; low and high end bracket the measured number.
By their numbers in this assay, from the lowest: compounds 4, 2 and 3 (each within the scatter of the next); then compound 1.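

Extending the hydroxy-bearing chain to 2-hydroxyethyl makes no readable difference, with a step of a 1.0-fold lower number from compound 2 to compound 4 (0.01 log units; within the scatter), so chain length between these two alcohols has little bearing on the number here. Replacing methylcarbamoyl with this chain also stays within the scatter, at a 1.9-fold lower number from compound 3 to compound 4 (0.27 log units; within the scatter), whereas replacing carboxy gives an 8.5-fold lower number from compound 1 to compound 4 (0.93 log units; beyond the scatter), which leaves compound 1 as the only one of the four set apart from the rest, and it has the highest number. No measurement shown here accounts for this separation.

Going by these compounds, what an amine or a plain alkyl chain carrying no hydroxy would give at this position remains open. So does whether a still longer alcohol chain would keep the number in the same range.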